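Removing the last double bonds from the chain

The source may report more compounds than this note shows. Statements on the series, on what has been measured and on what is new or still open speak of the compounds shown alone.

Within the data shown here, in a functional assay on MDA-MB-231 cells (Homo sapiens) for antiproliferative activity, read by MTT assay (a higher number here means a weaker inhibitor, a lower number a stronger inhibitor), compound 2 `CCCCC/C=C\C/C=C\CCCCCCCc1cc(=O)c2c(O)cc(OCOC)c(C)c2o1` gives 16100 nM, the higher of the two numbers so far, and compound 1 `CC/C=C\C/C=C\C/C=C\CCCCCCCc1cc(=O)c2c(O)cc(OCOC)c(C)c2o1` gives 6790 nM. Compound 3 `CCCCCCCCCCCCCCCc1cc(=O)c2c(O)cc(OCOC)c(C)c2o1` has octyl in place of deca-1,4-dien-1-yl, on a saturated chain carbon: octyl in place of deca-1,4-dien-1-yl on a saturated chain carbon, seven bonds along the chain from an aromatic carbon. Among the measured compounds shown here, the one measured step that bears on this is a 2.4-fold higher number from compound 1 to compound 2 (0.37 log units; beyond the scatter), a modest weakening that also took a double bond out of the chain. A further rise of similar or somewhat larger size is therefore expected in this assay. The estimated step is a 2.2-fold higher number from compound 2 to compound 3 (0.34 log units; beyond the scatter). For compound 3 the expected value is 35000 nM, with an estimated range of 16000 nM to 90000 nM.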

Compound 3, half-maximal inhibitory concentration: > 87000 nM
Compound 3 was reported as a limit; the forecaster's own chance of this, stated with the estimate: 15%; middle value at least 2.4-fold (0.39 log units) away from the limit.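

In this assay the saturated octyl chain loses far more than the first removal of a double bond did, with an at least 5.4-fold higher number from compound 2 to compound 3 (0.73 log units; beyond the scatter) and with an at least 12-fold higher number from compound 1 to compound 3 (1.10 log units; beyond the scatter) across the three compounds. Activity in this series therefore falls away sharply once the chain holds no double bond. The reading for compound 3 is a limit, not a number: the limit of > 87000 nM in this assay, at which 1 of the 3 values shown sits.

Octyl also has fewer carbons than deca-1,4-dien-1-yl, so the loss of the double bonds and the shortening of the chain cannot be told apart. A saturated decyl chain in the same place would separate the two.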